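The source may hold more compounds than are shown below. What is called first, only, known or untested is meant among the compounds shown, and "the series" means these compounds.

Measured in an ADME assay on MT4 cells (Homo sapiens) for cytotoxicity, read by MTT assay, with a stated time of 5 days; a higher number here means that more compound is tolerated, a lower number that less compound is tolerated:
- compound 1 `CNc1cc(Oc2c(OC)cc3cc(C#N)ccc3c2OC)nc(Nc2ccc(C#N)cc2)n1`: 239000 nM
- compound 2 `CCNc1cc(Oc2c(OC)cc3cc(C#N)ccc3c2OC)nc(Nc2ccc(C#N)cc2)n1`: > 125000 nM (a limit)
- compound 3 `COc1cc2cc(C#N)ccc2c(OC)c1Oc1cc(NC(C)(C)C)nc(Nc2ccc(C#N)cc2)n1`: > 125000 nM (a limit)

Compound 3 has no number in this assay. It stands at the limit of > 125000 nM in this assay, at which 2 of the 3 values shown sit.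

Compound 4 `CCCC(CCC)Nc1cc(Oc2c(OC)cc3cc(C#N)ccc3c2OC)nc(Nc2ccc(C#N)cc2)n1` has 1-propylbutyl in place of tert-butyl on a nitrogen on an aromatic ring.

Among the compounds with values here, the steps that bear on this change are those on the same nitrogen: a step that the limit leaves unreadable from compound 1 to compound 2, a step that the limit leaves unreadable from compound 1 to compound 3 and a step that the two limits leave unreadable from compound 2 to compound 3. None of them has a readable size, so they give neither a magnitude nor a direction for the new step. Across methyl, ethyl and tert-butyl on this nitrogen, the three compounds show no sign of less compound being tolerated, and no compound in the series goes against that. Within the data shown here, the series holds only one number, for compound 1 at 239000 nM, and the expectation leans on it. Among the measured compounds shown here, the larger chain in compound 4 has no measured precedent here, so the range is kept wide.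

The estimated step is a step that the limit leaves unreadable from compound 3 to compound 4, and none beyond the usual scatter is expected. For compound 4 the expected value is 130000 nM. The estimated range for compound 4 runs from 50000 nM to 260000 nM.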

Compound 4, half-maximal cytotoxic concentration: > 125000 nM
Compound 4 gave a limit, no number; the forecaster's own chance of this, stated with the estimate: 50%; the middle value is on the limit's open side.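

In this assay compound 4 gives > 125000 nM, which is a limit and not a number. Within the data shown here, no step from compound 1, compound 2 or compound 3 to compound 4 can be read, and the series stands at: the limit of > 125000 nM in this assay, at which 3 of the 4 values shown sit. On these data alone, whether any group on this nitrogen, from methyl to 1-propylbutyl, shifts the tolerated concentration remains open, as does the size of any difference among compound 2, compound 3 and compound 4.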